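Sulfonamide series: replacing 4-methylphenyl with an amide

The source may report more compounds than this note shows. Statements on the series, on what has been measured and on what is new or still open speak of the compounds shown alone.

- compound 1 `Cc1cc(C)c(S(=O)(=O)N2CCC(N3CCC(C)CC3)CC2)c(C)c1`: 0.03 nM
- compound 2 `Cc1ccc(C2CCN(S(=O)(=O)c3c(C)cc(C)cc3C)CC2)cc1`: 2200 nM
- compound 3 `CCCC(=O)NC1CCN(S(=O)(=O)c2c(C)cc(C)cc2C)CC1`: not yet measured

In a functional assay on DLD-1 cells (Homo sapiens) for antiproliferative activity, read by CellTiter-Glo, with a stated time of 72 h (on this read-out lower numbers stand for stronger inhibition and higher numbers for weaker inhibition), compound 2 gives the higher of the two numbers, 2200 nM. The next structure carries (propylcarbonyl)amino in place of 4-methylphenyl on a saturated ring carbon. Within the data shown here, the only measured step at this place is large: a 73000-fold higher number from compound 1 to compound 2 (4.87 log units; beyond the scatter). That step introduced 4-methylphenyl in place of 4-methylpiperidin-1-yl, and the incoming group here is not 4-methylpiperidin-1-yl, so no step beyond the scatter is expected in this assay. The expected step is a 1.5-fold lower number from compound 2 to compound 3 (0.17 log units; within the scatter). Compound 3 is estimated at 1500 nM, with an expected range from 150 nM to 10000 nM.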

Compound 3, half-maximal inhibitory concentration: > 5000 nM
Compound 3 ended at the assay's limit; the forecaster's own chance of this, stated with the estimate: 15%; at least 3.3-fold (0.52 log units) between middle value and limit.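

In this assay compound 3 gives a limit and not a number: the limit of > 5000 nM in this assay, at which 1 of the 3 values shown sits.

The amide is no gain over the aromatic group at this saturated ring carbon, and the change reads as a loss: an at least 2.2-fold higher number from compound 2 to compound 3 (0.35 log units; beyond the scatter). A second, unrelated replacement of 4-methylpiperidin-1-yl also falls far short, with an at least 160000-fold higher number from compound 1 to compound 3 (5.22 log units; beyond the scatter).

The compounds shown leave open which feature of 4-methylpiperidin-1-yl carries the activity. A piperidine without the methyl, or an open-chain dialkylamine, on the same carbon would separate the ring from the amine nitrogen.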